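This account rests on a few compounds, and the source may have more. Where it says the series, first, only, none or still open, it means among the compounds named here.

Compound 1 `Cn1c(-c2ccccc2Br)cnc1NC(=O)c1ccc(F)cc1` gives only a limit in a toxicity assay on THP-1 cells (Homo sapiens) for inhibition (a higher number here means that more compound is tolerated, a lower number that less compound is tolerated), > 100000 nM.
Compound 2 `Cc1ccc(-c2cnc(NC(=O)c3ccc(F)cc3)n2C)cc1` gives 60000 nM in this assay.

For the measured compounds named here, compound 2 thus holds the only number in this small set; the one other value is a limit (the limit of > 100000 nM in this assay, at which 1 of the 2 values shown sits). Compound 3 `Cc1cccc(-c2cnc(NC(=O)c3ccc(F)cc3)n2C)c1` differs from compound 2 by 3-methylphenyl in place of 4-methylphenyl on an aromatic carbon. Going by the values given here, the one measured step at that aromatic carbon, an at least 1.6-fold lower number from compound 1 to compound 2 (0.22 log units; that floor lies within the scatter), also swapped one phenyl ring for another, and its floor lies within the scatter, so it gives no direction. For compound 3 no step beyond the scatter is expected, no change at the digits printed from compound 2 to compound 3 (within the scatter). Compound 3 is therefore estimated at 60000 nM, between 30000 nM and 120000 nM.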

Compound 3, half-maximal cytotoxic concentration: > 100000 nM
Compound 3: no number, only a limit; the forecaster's own chance of this, stated with the estimate: 25%; at least 1.6-fold (0.22 log units) between middle value and limit.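

Replacing 4-methylphenyl with 3-methylphenyl at this aromatic carbon, with the same atoms joined differently, gives an at least 1.6-fold higher number from compound 2 to compound 3 (0.22 log units; that floor lies within the scatter) in this assay. From the compounds shown here alone, this floor does not separate the two compounds, and the true size of the step stays unknown. Compound 1 and compound 3 each stand at a limit, so the step between them cannot be read, and limits now make up most of the set: the limit of > 100000 nM in this assay, at which 2 of the 3 values shown sit.

The compounds shown leave open how a phenyl ring carrying an amine or a carboxylic acid at this carbon would read in this assay. They also leave open how far compound 3 actually lies from compound 2.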